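Series notes: from compound 3 to compound 4

This account rests on a few compounds, and the source may have more. Where it says the series, first, only, none or still open, it means among the compounds named here.

Compound 1 `CC(C)[C@H](NC(=O)COc1cccc2ccccc12)C(=O)N[C@@H](CC(=O)O)C(=O)CSc1nc(-c2ccccc2)c(-c2ccccc2)[nH]1`, compound 2 `CC(C)[C@H](NC(=O)COc1cccc2ccccc12)C(=O)N[C@@H](CC(=O)O)C(=O)CSc1nc(-c2ccccc2)c(-c2ccccc2)o1` and compound 3 `CC(C)[C@H](NC(=O)COc1cccc2ccccc12)C(=O)N[C@@H](CC(=O)O)C(=O)CSc1nnnn1C` share one core and differ only in the group on the saturated chain carbon bound to the carbonyl carbon. In a functional assay on Jurkat cells (Homo sapiens) for inhibition (on this read-out lower numbers stand for stronger inhibition and higher numbers for weaker inhibition), compound 1 reaches only the assay limit, > 200000 nM. Compound 2 likewise gives only a limit, > 200000 nM. Compound 3 also gives only a limit, > 200000 nM, so it stands indistinguishable from the other two within the numbers shown: the limit of > 200000 nM in this assay, at which 3 of the 3 values shown sit. For the measured compounds named here, no step between measured compounds exists in this set. Compound 4 `CC(C)[C@H](NC(=O)COc1cccc2ccccc12)C(=O)N[C@@H](CC(=O)O)C(=O)COc1nncc(Cl)c1Cl` differs from compound 3 by (4,5-dichloropyridazin-3-yl)oxy in place of (1-methyl-1H-tetrazol-5-yl)sulfanyl on a saturated chain carbon bound to a carbonyl carbon. With nothing measured beyond limits, the step is expected to run toward stronger inhibition, an at least 10-fold lower number from compound 3 to compound 4 (1.00 log units; beyond the scatter), as an estimate only. Compound 4 is expected near 20000 nM, between 2000 nM and 200000 nM.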

Compound 4, half-maximal inhibitory concentration: > 200000 nM
Compound 4: only a limit was reported; the forecaster's own chance of this, stated with the estimate: 35%; at least 10-fold (1.00 log units) between middle value and limit.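

In this assay, for the compounds shown here, compound 4 gives only a limit, > 200000 nM; compound 3 also gives only a limit, so no step between compound 3 and compound 4 can be read. The compounds shown leave open whether any group at this place on the shared core gives a value short of the limit in this assay.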